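Amide variation on the shared core: compound 3

The source may hold more compounds than are shown below. What is called first, only, known or untested is meant among the compounds shown, and "the series" means these compounds.

For the measured compounds named here, compound 2 `O=C(NC1CCCCC1)c1cc(Oc2ccc(/C=C/c3ccccn3)cc2)ccn1` stands lowest of the two numbers measured so far in a functional assay on A549 cells (Homo sapiens) for antiproliferative activity, read by CCK-8 assay, with a stated time of 48 h (on this read-out higher numbers stand for weaker inhibition and lower numbers for stronger inhibition), where compound 2 gives 12500 nM. Going by the values given here, its nearest neighbour is compound 1 `O=C(NC1CC1)c1cc(Oc2ccc(/C=C/c3ccccn3)cc2)ccn1`, which in this assay gives 17300 nM; the single measured step, a 1.4-fold lower number from compound 1 to compound 2 (0.14 log units; within the scatter), is cyclohexyl in place of cyclopropyl on an amide-type nitrogen and stays within the scatter.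

Compound 3 `O=C(c1cc(Oc2ccc(/C=C/c3ccccn3)cc2)ccn1)N1CCCC1` remains to be measured. The change from compound 2 is pyrrolidin-1-yl in place of cyclohexylamino on a carbonyl carbon. Among the compounds with values here, no measured step covers a change of this kind; the step from compound 1 to compound 2 bears on it only insofar as the group on the amide-type nitrogen could be exchanged without a shift beyond the scatter. With nothing further to go on, the expectation for this assay is a step of no more than the scatter in either direction, and the uncertainty is accordingly wide. Compound 3 is therefore estimated to give 15000 nM, with a range from 5000 nM to 45000 nM, which as an expected step reads a 1.2-fold higher number from compound 2 to compound 3 (0.08 log units; within the scatter).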

Compound 3, half-maximal inhibitory concentration: 15600 nM
Beside the measured number, compound 3's estimate is 1.0-fold (0.02 log units) below it; low and high end bracket the measured number.
By their numbers in this assay, from the lowest: compounds 2, 3 and 1 (each within the scatter of the next).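

Notes on the amide position. In this assay, the group on the carbonyl carbon has now been changed from a secondary to a tertiary amide: pyrrolidin-1-yl, with 0 hydrogen-bond donors, replaces cyclohexylamino, with 1, giving a 1.2-fold higher number from compound 2 to compound 3 (0.10 log units; within the scatter) and, against the cyclopropylamino group, a 1.1-fold lower number from compound 1 to compound 3 (0.04 log units; within the scatter) within the same read-out. Across compounds 1, 2 and 3, therefore, neither the amide hydrogen nor the change from an open attachment through nitrogen to a ring closed on that nitrogen shifts the number beyond the scatter, which extends the earlier finding from a swap of ring size on a secondary amide to a swap of amide type. No measurement on these compounds offers an explanation for this flat stretch of the series.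

From the compounds shown here alone, what remains open is whether any group at this position can move the number beyond the scatter, for example a longer chain carrying an amine on the amide-type nitrogen, or a carboxylic acid in place of the amide. The three compounds also leave the rest of the shared core untouched, so they say nothing about how much of the activity depends on the parts outside this position.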